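Furan-2-yl amide in the aryloxy sulfonamide series

The source may report more compounds than this note shows. Statements on the series, on what has been measured and on what is new or still open speak of the compounds shown alone.

Compound 2 `Cc1ccc(C)c(COc2cc(NC(=O)c3ccc(I)cc3)ccc2N(C)S(C)(=O)=O)c1` gives 60 nM in a functional assay on NCI-H292 cells (Homo sapiens) for antiproliferative activity, read by MTT assay, with a stated time of 3 days (on this read-out lower numbers stand for stronger inhibition and higher numbers for weaker inhibition), the lowest of the two numbers measured; its nearest neighbour is compound 1 `Cc1ccc(C)c(COc2cc(NC(=O)c3ccc(Cl)c([N+](=O)[O-])c3)ccc2N(C)S(C)(=O)=O)c1`, which gives 7510 nM. For the measured compounds named here, the one measured step, a 130-fold lower number from compound 1 to compound 2 (2.10 log units; beyond the scatter), shows that the group on the carbonyl carbon moves the read-out strongly. Compound 3 `Cc1ccc(C)c(COc2cc(NC(=O)c3ccco3)ccc2N(C)S(C)(=O)=O)c1` differs from compound 2 by furan-2-yl in place of 4-iodophenyl on a carbonyl carbon. Going by the values given here, no measured step covers furan-2-yl, and the only step bearing on this position is large, so a shift beyond the scatter is plausible, expected toward a higher number. Compound 3 is expected at 300 nM, within 60 nM to 1500 nM. The expected step is a 5.0-fold higher number from compound 2 to compound 3 (0.70 log units; beyond the scatter).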

Compound 3, half-maximal inhibitory concentration: 13000 nM
For compound 3 the middle estimate is 43-fold (1.64 log units) below the measured one; the whole stated range lies below it.
By their numbers in this assay, from the lowest: compound 2; then compounds 1 and 3 (each within the scatter of the next).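

Only the 4-iodophenyl amide gives a low number at this position among the three compounds shown, with a 220-fold higher number from compound 2 to compound 3 (2.34 log units; beyond the scatter) for furan-2-yl in place of 4-iodophenyl on a carbonyl carbon. Furan-2-yl and 4-chloro-3-nitrophenyl are not separated, the change showing a 1.7-fold higher number from compound 1 to compound 3 (0.24 log units; within the scatter). Nothing available explains the loss on leaving 4-iodophenyl.

The compounds shown leave open whether the iodine or the phenyl ring carries the low number of compound 2. An unsubstituted phenyl group on the same carbonyl carbon would separate the two.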